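The compounds below may be only part of what the source reports. "The series", "measured", "known", "first", "only" and "open" are said of these compounds alone.

Measured so far in a functional assay on T47D cells (Homo sapiens) for cytotoxicity, read by MTT assay, with a stated time of 48 h; on this read-out higher numbers stand for weaker inhibition and lower numbers for stronger inhibition:
Compound 1 (`COc1ccc(NC(=S)N/N=C\c2ccnc3ccccc23)cc1`) gives 1360 nM
Compound 2 (`CCc1ccc(NC(=S)N/N=C\c2ccnc3ccccc23)cc1`) gives 1280 nM
Compound 3 (`Fc1ccc(NC(=S)N/N=C\c2ccnc3ccccc23)cc1`) gives 1070 nM

Compound 2 (1280 nM) cannot be told apart from the other two. The measured steps (a 1.1-fold lower number from compound 1 to compound 2 (0.03 log units; within the scatter)), (a 1.2-fold lower number from compound 2 to compound 3 (0.08 log units; within the scatter)) and (a 1.3-fold lower number from compound 1 to compound 3 (0.10 log units; within the scatter)) all lie within the scatter.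

Compound 4 (`C=CCNC(=S)N/N=C\c1ccnc2ccccc12`) carries allyl in place of 4-ethylphenyl on an amide-type nitrogen. The measured steps bear on this change only weakly. Within the data shown here, each exchanges one group on an aromatic carbon, whereas here the whole aromatic ring leaves, and no measured compound lacks that ring. Their small size, the widest being (a 1.3-fold lower number from compound 1 to compound 3 (0.10 log units; within the scatter)), therefore gives no real measure of this larger change. A moderate move towards weaker inhibition in this assay is expected, though the direction is uncertain, and the estimated step is (a 2.3-fold higher number from compound 2 to compound 4 (0.37 log units; beyond the scatter)). Compound 4 is estimated at 3000 nM in the middle, with an expected range from 1000 nM to 10000 nM as its ends.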

Compound 4, half-maximal inhibitory concentration: 1230 nM
Compound 4: middle estimate off by 2.4-fold (0.39 log units), on the high side, within the range that was stated.
By their numbers in this assay, from the lowest: compounds 3, 4, 2 and 1 (each within the scatter of the next).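

In this assay, among these compounds, the earlier compounds varied only one group on the aromatic ring, whereas compound 4 shows that the whole 4-substituted phenyl group on the amide-type nitrogen can give way to allyl with no change that stands out from the scatter (a 1.0-fold lower number from compound 2 to compound 4 (0.02 log units; within the scatter)). The same holds for the two other aryl compounds (a 1.1-fold higher number from compound 3 to compound 4 (0.06 log units; within the scatter)) and (a 1.1-fold lower number from compound 1 to compound 4 (0.04 log units; within the scatter)), so among these four compounds an aromatic ring at this position is not required for inhibition at this level. Nothing available here explains this result.

On these data alone, it remains open whether a propyl group, a longer chain, or a chain ending in an amine or a carboxylic acid on this nitrogen would move the number beyond the scatter. As far as these compounds go, it is also open whether the allyl double bond matters at all.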